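The source may report more compounds than this note shows. Statements on the series, on what has been measured and on what is new or still open speak of the compounds shown alone.

The two measured compounds share a core and differ in how the hydroxamic acid arm is attached to it. Compound 1 `COc1ccc(C(=O)c2ccc3c(ccn3S(=O)(=O)c3ccc(/C=C/C(=O)NO)cc3)c2)cc1` carries a sulfonyl-linked arm and, in an assay on isolated protein for inhibition of histone deacetylase 8 (Homo sapiens) (on this read-out higher numbers stand for weaker inhibition and lower numbers for stronger inhibition), gives 10000 nM. Compound 2 `O=C(NO)c1ccc(Cn2ccc3cc(C(=O)c4ccc(F)cc4)ccc32)cc1` carries a benzyl-linked arm and in this assay gives 1240 nM. Of the two numbers, compound 2 stands lowest; the number for compound 1 is higher by a gap that lies beyond the usual scatter. Compound 3 `Cc1ccc(C(=O)c2ccc3c(ccn3Cc3ccc(C(=O)NO)cc3)c2)cc1` has not yet been measured. It differs from compound 2 in one place: methyl in place of fluoro on an aromatic carbon. For the measured compounds named here, no step between measured compounds isolates this exchange, so the expectation rests only on the small size of the change and on the number for compound 2. The step of a 1.2-fold higher number from compound 2 to compound 3 (0.08 log units; within the scatter) is expected to stay within the scatter, with no direction beyond it. Compound 3 is therefore estimated to give 1500 nM in this assay, with a range from 500 nM to 4500 nM.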

Compound 3, half-maximal inhibitory concentration: 1490 nM
Beside the measured number, compound 3's estimate is 1.0-fold (0.00 log units) above it; the measured number falls inside the stated range.
By their numbers in this assay, from the lowest: compounds 2 and 3 (each within the scatter of the next); then compound 1.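

In this assay, for the compounds shown here, the exchange of 4-fluorophenyl for 4-methylphenyl gives a 1.2-fold higher number from compound 2 to compound 3 (0.08 log units; within the scatter) and is the first change in this set that can be read on its own. On this read-out, fluoro and methyl on the aromatic carbon para to a large group cannot be told apart, so this position accepts either of these single heavy atoms, neither of which counts as a hydrogen-bond donor or acceptor, without a change beyond the scatter; this finding rests on this one pair alone. Nothing measured here speaks to what lies behind this result.

The compounds shown leave open whether the same position would remain as undemanding with an amine, a carboxylic acid or a longer chain such as butyl in place of fluoro or methyl. They also leave open which feature of compound 1 sets its number, since it differs from compound 2 and compound 3 in more than one place and no single change can be tied to it.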